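Furan Amide Variant of a Series with Low Inhibition Read-outs

A few compounds are considered here, and "the series" means these few. Any claim that something is new, unique, unknown or untested is made for them only; others in the source may bear on it.

Measured compounds:
compound 1 `CC(C)=CCOc1cc(=O)n(CCCO)c2c1CC(CC=C(C)C)C(C)(C)C2`: 7.5%
compound 2 `COc1ccc(C(=O)NCCCOc2cc(=O)n(CCCO)c3c2CC(CC=C(C)C)C(C)(C)C3)cc1`: 2.5%

In a functional assay on PANC-1 cells (Homo sapiens) for inhibition, read by MTT assay, with a stated time of 24 h, tested at 10 uM (on this read-out higher numbers stand for more inhibition at the one concentration tested (going by the name of the read-out) and lower numbers for less inhibition), compound 1 gives 7.5% and compound 2 gives 2.5%. Compound 2 stands lowest of the two numbers, yet its gap to compound 1 lies within the usual scatter, so the two cannot be set in order. Both read out as slight inhibition at the single concentration tested.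

Compound 3 `CC(C)=CCC1Cc2c(OCCCNC(=O)c3ccco3)cc(=O)n(CCCO)c2CC1(C)C` is the next member. It differs from compound 2 in one place: furan-2-yl in place of 4-methoxyphenyl on a carbonyl carbon. For the measured compounds named here, no pair of measured compounds differing in a single place is available, so nothing here shows how such a swap shifts this assay. With both measured compounds near the floor of the read-out, the step from compound 2 to compound 3 is expected to be a number 2.5 percentage points higher from compound 2 to compound 3 (within the scatter), no larger than the scatter, in no settled direction. Compound 3 is accordingly estimated at 5%, within -5% to 15%.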

Compound 3, a percentage reported as inhibition, at one concentration (the size of the read-out at that concentration, not a potency): 4.3%
Compound 3: the middle estimate sits 0.7 percentage points above what was measured; the measured number falls inside the stated range.
By their numbers in this assay, from the lowest: compounds 2, 3 and 1 (each within the scatter of the next).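

In this assay, the series now has its first comparisons of compounds that differ in one place. Furan-2-yl in place of 4-methoxyphenyl on a carbonyl carbon gives a number 1.8 percentage points higher from compound 2 to compound 3 (within the scatter), and 2-(((furan-2-yl)carbonyl)amino)ethyl in place of 2-methylprop-1-en-1-yl on a saturated chain carbon bound to an oxygen on an aromatic ring gives a number 3.2 percentage points lower from compound 1 to compound 3 (within the scatter), so neither change moves the read-out beyond the scatter. Nothing available explains either step.

The compounds shown leave open whether a piperidine or a carboxylic acid in place of furan-2-yl on that carbonyl carbon would shift this assay beyond the scatter. On these data alone, it also remains open whether a longer chain carrying the same amide would do so.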